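Replacing pyridin-4-yl with 2-methoxyphenyl on the furoic acid core

The source may hold more compounds than are shown below. What is called first, only, known or untested is meant among the compounds shown, and "the series" means these compounds.

Measured so far:
compound 1, `Cc1oc(C(=O)O)cc1COc1ccc(-c2ccncc2)cc1`, > 10000 nM
compound 2, `Cc1oc(CCC(=O)O)cc1COc1ccc(-c2ccccc2)cc1`, 80 nM
compound 3, `Cc1oc(CC(=O)O)cc1COc1ccc(-c2ccccc2)cc1`, 80 nM

In an assay on cells for displacement of a labelled ligand from prostaglandin E2 receptor EP4 subtype (Homo sapiens), read by scintillation counting (on this read-out lower numbers stand for stronger inhibition and higher numbers for weaker inhibition), compound 1 gives > 10000 nM, which is a limit of the assay rather than a number. That limit is the limit of > 10000 nM in this assay, at which 1 of the 3 values shown sits. Among the measured compounds shown here, compound 2 gives 80 nM, and compound 3 gives 80 nM; the only step between measured compounds, no change at the digits printed from compound 2 to compound 3 (within the scatter), concerns the acid-bearing chain and not the distal aryl group.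

Compound 4, `COc1ccccc1-c1ccc(OCc2cc(C(=O)O)oc2C)cc1`, is not yet measured. It differs from compound 1 by 2-methoxyphenyl in place of pyridin-4-yl on an aromatic carbon. For the measured compounds named here, no measured step changes the distal aryl group, so none bears directly on this change. Compounds 2 and 3 carry a carbon-only ring at that place together with a longer acid-bearing chain, and both differ from compound 1 in two places, so their values cannot be assigned to either change alone. Compound 4 keeps the short acid of compound 1 while taking a carbon-only ring, so the author expects a gain in this assay of uncertain size, an at least 6.6-fold lower number from compound 1 to compound 4 (0.82 log units; beyond the scatter), bounded by the fact that the value for compound 1 is only a limit. The estimate for compound 4 is 1500 nM, expected to lie between 150 nM and 10000 nM.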

Compound 4, inhibition constant: 1600 nM
Estimate against measurement, compound 4: 1.1-fold (0.03 log units) below; the measured number falls inside the stated range.
By their numbers in this assay, from the lowest: compounds 2 and 3 (each within the scatter of the next); then compound 4. At a limit, above all of these: compound 1.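

In this assay, 2-methoxyphenyl in place of pyridin-4-yl on an aromatic carbon, para to a large group, gives an at least 6.2-fold lower number from compound 1 to compound 4 (0.79 log units; beyond the scatter). Among the compounds shown here, this is the first step read at the distal aryl group, and it shows that this position matters with the short acid of the core held constant, whereas the earlier step concerned only the acid-bearing chain. Compound 1 gives > 10000 nM, which is a limit of the assay and not a number, so the step has a floor but no known size: the limit of > 10000 nM in this assay, at which 1 of the 4 values shown sits.

The change removes a ring nitrogen and brings in a methoxy group at once, and a plain phenyl on the short acid of compound 1 would be needed to tell these two parts apart. On these data alone, it also remains open how a chloro or an amino group would read on this ring, and whether 2-methoxyphenyl would give a comparable result on the longer acid-bearing chains of compound 2 and compound 3.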